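The source may report more compounds than this note shows. Statements on the series, on what has been measured and on what is new or still open speak of the compounds shown alone.

Measured so far:
compound 1 `CCOc1ccc(CCCN2CC=C(CCC(=O)NO)C2=O)cc1` gives 2520 nM in a functional assay on NCI-H23 cells (Homo sapiens) for inhibition, read by sulforhodamine B assay; a higher number here means a weaker inhibitor of growth, a lower number a stronger inhibitor of growth
compound 2 `Cc1ccc(CCCN2CC=C(CCC(=O)NO)C2=O)cc1` gives 2520 nM in this assay

Compound 2 stands level with compound 1 in this assay: the step of no change at the digits printed from compound 1 to compound 2 (within the scatter) lies within the scatter. Compound 3 `CC(C)c1ccc(CCCN2CC=C(CCC(=O)NO)C2=O)cc1` differs from compound 2 by isopropyl in place of methyl on an aromatic carbon. Among the compounds with values here, the only measured step bearing on this change is the one at the same aromatic carbon, no change at the digits printed from compound 1 to compound 2 (within the scatter), and it was flat. No step beyond the scatter is therefore expected in this assay for compound 3. Compound 3 is estimated at 2500 nM, with a range of 1200 nM to 5200 nM. The expected step is a 1.0-fold lower number from compound 2 to compound 3 (0.00 log units; within the scatter).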

Compound 3, concentration for 50% growth inhibition: 2520 nM
Beside the measured number, compound 3's estimate is 1.0-fold (0.00 log units) below it; the measured number falls inside the stated range.
By their numbers in this assay, from the lowest: compounds 1, 2 and 3 (each within the scatter of the next).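

In this assay, isopropyl in place of methyl on this aromatic carbon gives no change at the digits printed from compound 2 to compound 3 (within the scatter) and isopropyl in place of ethoxy gives no change at the digits printed from compound 1 to compound 3 (within the scatter) at the same carbon. The flat reading now covers a third group, with 3 heavy atoms and no oxygen, so methyl, ethoxy and isopropyl stand level here. Nothing available accounts for this flat reading.

On these data alone, whether an amine or a carboxylic acid on this carbon would stay level remains open. So does whether a longer chain in place of the propyl linker would move the number.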